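The source may report more compounds than this note shows. Statements on the series, on what has been measured and on what is new or still open speak of the compounds shown alone.

In a functional assay on HEp-2 cells (Homo sapiens) for antiproliferative activity, read by MTT assay, with a stated time of 72 h (on this read-out higher numbers stand for weaker inhibition and lower numbers for stronger inhibition), three compounds have so far been measured. Compound 1 `O=c1c(Cl)c(CSC(=S)N2CCOCC2)oc2ccccc12` gives 9000 nM, compound 2 `O=c1cc(CSC(=S)N2CCCCC2)oc2cc(Cl)ccc12` gives 1600 nM, and compound 3 `COc1ccc2oc(CSC(=S)N3CCOCC3)cc(=O)c2c1` gives 3000 nM. On these numbers compound 2 stands lowest of the three; its gap to compound 3 lies within the usual scatter of repeated measurements, while its gap to compound 1 lies beyond it. Compound 4 `O=c1cc(CSC(=S)N2CCOCC2)oc2cc(Cl)ccc12` has not yet been measured in this assay. It differs from compound 2 in one place: morpholin-4-yl in place of piperidin-1-yl on a thiocarbonyl carbon. Within the data shown here, compound 1 and compound 3 both carry morpholin-4-yl, but each also differs from compound 2 elsewhere, so no measured pair isolates this change and no measured step tells its size. A small step toward a higher number, not clearly beyond the scatter, is expected. The step expected here is a 1.9-fold higher number from compound 2 to compound 4 (0.27 log units; within the scatter). Compound 4 is accordingly expected to give 3000 nM in this assay, within a range from 1200 nM to 8000 nM.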

Compound 4, half-maximal inhibitory concentration: 20600 nM
For compound 4 the middle estimate is 6.9-fold (0.84 log units) below the measured one; measured number outside the range, above it.
By their numbers in this assay, from the lowest: compounds 2 and 3 (each within the scatter of the next); then compound 1; then compound 4.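

In this assay, a 13-fold higher number from compound 2 to compound 4 (1.11 log units; beyond the scatter) gives the first measured size for morpholin-4-yl in place of piperidin-1-yl on a thiocarbonyl carbon, and this step is large and beyond the scatter. The earlier compounds shown here could not isolate this change, but here the rest of the structure stays the same, so the group on the thiocarbonyl carbon clearly matters to the read-out on the core of compound 2. Both groups are six-membered non-aromatic rings, and morpholin-4-yl differs by an oxygen in place of a ring carbon, counted as 1 hydrogen-bond acceptor.

From the compounds shown here alone, it remains open whether the exchange would have a similar size on the cores of compound 1 and compound 3, and where thiomorpholin-4-yl, 4-methylpiperazin-1-yl or an open-chain diethylamino group would fall at this place. Nothing shown here accounts for the size of the step.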